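This account rests on a few compounds, and the source may have more. Where it says the series, first, only, none or still open, it means among the compounds named here.

Measured in a functional assay on the whole organism (strain Albino) with Mus musculus as the target, with a stated time of 0.5 h; a higher number here means that more compound is needed for the effect, a lower number that less compound is needed:

Compound 1, `COc1ccc(/C(C)=N\NC(=O)Nc2nc(-c3ccc(F)cc3)cc(-c3ccc([N+](=O)[O-])cc3)n2)cc1`, gives 100 mg/kg.
Compound 2, `C/C(=N/NC(=O)Nc1nc(-c2ccc(C)cc2)cc(-c2ccc(F)cc2)n1)c1ccc(Cl)cc1`, gives 100 mg/kg.

Compound 2 stands level with compound 1 at the digits shown; the two values lie within the usual scatter, and since these two compounds differ at more than one place, no single step can be read from them. Compound 3, `COc1ccc(-c2cc(-c3ccc(F)cc3)nc(NC(=O)N/N=C(/C)c3ccc(Cl)cc3)n2)cc1`, is not yet measured. It differs from compound 2 by methoxy in place of methyl on an aromatic carbon. For the measured compounds named here, no step between measured compounds covers this change, so the expectation rests on the two values alone: compound 1 also carries a methoxy on an aromatic ring and gives 100 mg/kg, which sits level with compound 2. Compound 3 is therefore expected to show a step of no change at the digits printed from compound 2 to compound 3 (within the scatter), that is, no change beyond the scatter. The estimated dose for compound 3 in this assay is 100 mg/kg, with a range from 50 mg/kg to 200 mg/kg.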

Compound 3, dose for half-maximal effect: 300 mg/kg
Estimate against measurement, compound 3: 3.0-fold (0.48 log units) below; measured number outside the range, above it.
By their numbers in this assay, from the lowest: compounds 1 and 2 (each within the scatter of the next); then compound 3.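

In this assay, the change from 4-methylphenyl to 4-methoxyphenyl gives a 3.0-fold higher number from compound 2 to compound 3 (0.48 log units; beyond the scatter), so more compound is needed for the effect once methoxy replaces methyl. For the compounds shown here, this is the first step that can be read at a single place, and it shows that the aromatic carbon para to a large group is not indifferent to this exchange, at least in this one pair. Nothing measured here bears on why the number rises.

Going by these compounds, it remains open whether a hydroxyl or an amine at this place would need more or less compound than methyl, and whether a longer chain such as ethoxy would extend the step. On these data alone, it is also open whether the same exchange elsewhere on the shared core would give a step of similar size.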